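Series notes: 3-methylphenyl to 3-chlorophenyl step

A few compounds are considered here, and "the series" means these few. Any claim that something is new, unique, unknown or untested is made for them only; others in the source may bear on it.

Measured so far:
compound 1, `CCOC(=O)c1c(-c2cc3ccccc3oc2=O)nn(-c2cccc(Cl)c2)c1C(=O)OCC`, 35000 nM
compound 2, `CCOC(=O)c1c(-c2cc3ccc(OC)cc3oc2=O)nn(-c2cccc(C)c2)c1C(=O)OCC`, 35000 nM

In a functional assay on DU-145 cells (Homo sapiens) for cytotoxicity, read by MTT assay, with a stated time of 48 h (on this read-out higher numbers stand for weaker inhibition and lower numbers for stronger inhibition), compound 1 gives 35000 nM. In this assay compound 2 gives 35000 nM; compound 2 stands level with compound 1 at the digits shown, within the scatter. Compound 3, `CCOC(=O)c1c(-c2cc3ccc(OC)cc3oc2=O)nn(-c2cccc(Cl)c2)c1C(=O)OCC`, differs from compound 2 by chloro in place of methyl on an aromatic carbon. Among the compounds with values here, no measured pair isolates this change, and both measured compounds sit at the same figure, so no step beyond the scatter is expected. Compound 3 is estimated at 35000 nM, range 15000 nM to 80000 nM. The expected step of no change at the digits printed from compound 2 to compound 3 (within the scatter) is none beyond the scatter.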

Compound 3, half-maximal inhibitory concentration: 38000 nM
Beside the measured number, compound 3's estimate is 1.1-fold (0.04 log units) below it, within the range that was stated.
By their numbers in this assay, from the lowest: compounds 1, 2 and 3 (each within the scatter of the next).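

In this assay, chloro in place of methyl on an aromatic carbon, meta to a large group, gives a 1.1-fold higher number from compound 2 to compound 3 (0.04 log units; within the scatter), so this position shows no step beyond the scatter for this exchange. Methoxy in place of hydrogen on an aromatic carbon gives a 1.1-fold higher number from compound 1 to compound 3 (0.04 log units; within the scatter), so that change also shows no step beyond the scatter with chloro in place. No evidence bears on why these values stay level.

As far as these compounds go, whether an amine or a carboxylic acid at the position of the chloro would shift the read-out remains open. So does whether either change would behave the same way on a different core.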